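The compounds below may be only part of what the source reports. "The series", "measured", "known", "first", "only" and "open" are said of these compounds alone.

Compound 3 `COc1ccccc1-n1nc([C@@H]2CCO[C@@H](C(C)C)C2)cc1-c1ccc(Cl)cc1` has in an assay on HEK293 cells for inhibition of Voltage-dependent N-type calcium channel subunit alpha-1B (Homo sapiens), read by patch clamp, using a membrane potential dye (a higher number here means a weaker inhibitor, a lower number a stronger inhibitor), only the entry "not determined" (no result reported), so it stands nowhere on the numbers shown. Two related compounds set the frame. Compound 1 `COc1ccccc1-n1nc([C@H]2C[C@@H](C)O[C@@H](C)C2)cc1-c1ccc(Cl)cc1` gives 12 nM in this assay, and compound 2 `COc1ccccc1-n1nc(C2C[C@H](C)O[C@@H](C)C2)cc1-c1ccc(Cl)cc1` gives 61000 nM. The step of a 5100-fold higher number from compound 1 to compound 2 (3.71 log units; beyond the scatter) is the only measured one, and it concerns configuration alone; the fact that one of compounds 1 and 2 is drawn with a defined configuration and the other without, at the place where they differ is the evidence that bears on it, since the atoms and bonds are the same in both compounds.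

Compound 4 `COc1ccccc1-n1nc([C@@H]2CCO[C@H](C(C)C)C2)cc1-c1ccc(Cl)cc1` is reached from compound 3 by the two compounds have the same atoms and bonds and differ only in configuration as drawn: 1 of 2 stereo elements differ; a stereocentre at a saturated ring carbon is drawn R in compound 3 and S in compound 4. Within the data shown here, only that one stereocentre changes. The measured step shows that a change in configuration at a saturated ring carbon of this shared core can move the number in this assay a very long way, well beyond the scatter. Compound 3 has no number of its own, so the direction for compound 4 cannot be read from it: compound 4 may sit near either end of what compounds 1 and 2 mark out. The account therefore expects a wide spread rather than a sharp figure. Compound 4 is estimated at 1000 nM in this assay, with a range from 10 nM to 60000 nM.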

Compound 4, half-maximal inhibitory concentration: 55000 nM
For compound 4 the middle estimate is 55-fold (1.74 log units) below the measured one; the measured number falls inside the stated range.
By their numbers in this assay, from the lowest: compound 1; then compounds 4 and 2 (each within the scatter of the next).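

In this assay, compound 4 joins compound 2 at the high end of the numbers, with a 1.1-fold lower number from compound 2 to compound 4 (0.04 log units; within the scatter), so this exchange of 2-isopropyloxan-4-yl for 2,6-dimethyloxan-4-yl leaves the two compounds indistinguishable. Set against the other dimethyl compound, the same exchange gives a 4600-fold higher number from compound 1 to compound 4 (3.66 log units; beyond the scatter), which leaves compound 1 as the only compound with a low number and shows that a high number at this place on the shared core is not confined to the 2,6-dimethyloxan-4-yl group. The step from compound 3 to compound 4 cannot be read, as compound 3 has no number, so the size of this one change stays unknown even though its nature is clear: the fact that compounds 3 and 4 differ only in the configuration as drawn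

The compounds shown leave open whether the 2-isopropyloxan-4-yl group in the configuration of compound 3 would give a number near that of compound 1 or near that of compound 4. They also leave open how a 2-ethyloxan-4-yl or 2-tert-butyloxan-4-yl group would fare in this assay, in either configuration.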